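The compounds below may be only part of what the source reports. "The series", "measured", "known", "first", "only" and "open" are said of these compounds alone.

Compound 1, `CC(C)S(=O)(=O)OC1CCC(CN2CCN(c3cc(=O)c4cc(C(F)(F)F)cc([N+](=O)[O-])c4s3)CC2)CC1`: in an ADME assay on Vero cells (Chlorocebus sabaeus) for cytotoxicity, read by MTT assay, with a stated time of 48 h (a higher number here means a weaker inhibitor, a lower number a stronger inhibitor), compound 1 gives > 64 ug/mL, which is a limit of the assay.
Compound 2, `CS(=O)(=O)NC1CCC(CN2CCN(c3cc(=O)c4cc(C(F)(F)F)cc([N+](=O)[O-])c4s3)CC2)CC1`: in this assay compound 2 gives 48.5 ug/mL.
Compound 3, `O=C(OC1CCC(CN2CCN(c3cc(=O)c4cc(C(F)(F)F)cc([N+](=O)[O-])c4s3)CC2)CC1)c1cccc(C(F)(F)F)c1`: in this assay compound 3 gives > 64 ug/mL, which is a limit of the assay.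

Going by the values given here, compound 2 holds the only number among the three; the two other values are limits. The unmeasured compound 4, `CC(C)C(=O)OC1CCC(CN2CCN(c3cc(=O)c4cc(C(F)(F)F)cc([N+](=O)[O-])c4s3)CC2)CC1`, differs from compound 2 by (isopropylcarbonyl)oxy in place of methanesulfonamido on a saturated ring carbon. Among the compounds with values here, the one readable step that touches compound 2 is an at least 1.3-fold lower number from compound 1 to compound 2 (0.12 log units; that floor lies within the scatter), and it runs the other way, from an oxygen-linked group to methanesulfonamido, with a size that stays within the scatter. The step that the two limits leave unreadable from compound 1 to compound 3 gives no size, since both of its values are limits. What the set does show is the limit of > 64 ug/mL in this assay, at which 2 of the 3 values shown sit, and both compounds that sit there, compound 1 and compound 3, carry an oxygen-linked group on the saturated ring carbon, as compound 4 will. Compound 4 is therefore expected to return toward that limit, with a 1.3-fold higher number from compound 2 to compound 4 (0.12 log units; within the scatter) as the estimated step, modest and in the direction of a higher number. The estimate for compound 4 in this assay is 64 ug/mL, with a range from 32 ug/mL to 128 ug/mL, and a good chance that only a limit is reported.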

Compound 4, half-maximal inhibitory concentration: > 64 ug/mL
Compound 4: a limit, no number (the forecaster's own chance of this, stated with the estimate: 60%); the middle value sits exactly at the limit.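

Compound 4 adds a third oxygen-linked group on the saturated ring carbon, three ring bonds from the ring atom that bears a large group, and this time the comparison with methanesulfonamido is direct. In this assay, the change from methanesulfonamido to (isopropylcarbonyl)oxy gives an at least 1.3-fold higher number from compound 2 to compound 4 (0.12 log units; that floor lies within the scatter), so the two groups are not separated beyond the scatter, and the steps from compound 1 and from compound 3 to compound 4 cannot be read, as each joins two limits. Even so, an isopropyl on the carbonyl now reads as a limit, as the 3-(trifluoromethyl)phenyl on the carbonyl of compound 3 and the isopropylsulfonyl on the oxygen of compound 1 do, and among the compounds shown only methanesulfonamido gives a number, a pattern that no compound shown goes against: the limit of > 64 ug/mL in this assay, at which 3 of the 4 values shown sit.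

The three limits give no order among compound 1, compound 3 and compound 4. Going by these compounds, it also remains open how a free hydroxyl, an amine or a carboxylic acid on that saturated ring carbon would read in this assay.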